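The compounds below may be only part of what the source reports. "The series", "measured", "known", "first", "only" and "open" are said of these compounds alone.

Measured so far in a functional assay on MCF7 cells (Homo sapiens) for cytotoxicity, read by MTT assay, with a stated time of 72 h; on this read-out lower numbers stand for stronger inhibition and higher numbers for weaker inhibition:
compound 1 `Cc1ccc(-c2ccc(C(=O)Nc3ccc(Oc4ccnc5[nH]ccc45)cc3)nc2)cc1` gives > 10000 nM, which is a limit of the assay and not a number.
compound 2 `O=C(Nc1ccc(Oc2ccnc3[nH]ccc23)cc1)c1cc(-c2ccc(C(F)(F)F)cc2)ccn1` gives > 10000 nM, again a limit of the assay rather than a number.

Both compounds share the same core and differ only in the group on the outer aromatic ring. Compound 2 has no measured number on this read-out; it stands at the limit of > 10000 nM in this assay, at which 2 of the 2 values shown sit. Nothing in these two results tells which of the two is the stronger inhibitor, since neither reached a value inside the measured range.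

The next compound, compound 3 `O=C(Nc1ccc(Oc2ccnc3[nH]ccc23)cc1)c1cc(-c2ccccc2)ccn1`, is reached from compound 2 by hydrogen in place of trifluoromethyl on an aromatic carbon. Going by the values given here, no step between measured compounds is available here, so the size of this change in this assay cannot be read from earlier data. With both known values at the limit, the expectation is that compound 3 stays near that limit, with no step beyond the scatter in either direction. Compound 3 is expected to give about 15000 nM in this assay, most likely between 4000 nM and 60000 nM. This means an expected step that the limit leaves unreadable from compound 2 to compound 3.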

Compound 3, half-maximal inhibitory concentration: 3750 nM
For compound 3 the middle estimate is 4.0-fold (0.60 log units) above the measured one; measured number below the stated range.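

In this assay, going from 4-(trifluoromethyl)phenyl to phenyl gives an at least 2.6-fold lower number from compound 2 to compound 3 (0.42 log units; beyond the scatter). Going by these compounds alone, this is the first sign in these compounds that the group on this aromatic carbon matters: with hydrogen in place of trifluoromethyl, the read-out falls inside the measured range, and lower numbers here mean stronger inhibition. The full size of the step cannot be told, since compound 2 carries only a limit of the assay and no number of its own: the limit of > 10000 nM in this assay, at which 2 of the 3 values shown sit.

Going by these compounds, whether a methoxy group, an amine or a carboxylic acid on this same carbon would lower the number further or raise it again stays open, so a single replacement cannot show whether hydrogen is the best choice here or whether trifluoromethyl is simply a poor one. On these data alone, it also stays open whether the same change would have a similar effect on a different core, or in cells other than those of this assay, as this one step comes from one pair of compounds in one assay.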